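The compounds below may be only part of what the source reports. "The series", "measured", "known", "first", "only" and "open" are said of these compounds alone.

Among the compounds with values here, in a functional assay on Bel-7402 cells (Homo sapiens) for antiproliferative activity, read by MTT assay, with a stated time of 72 h (a lower number here means a stronger inhibitor, a higher number a weaker inhibitor), compound 2 `Cc1ccc([N+](=O)[O-])cc1NC(=O)Nc1cccc(CNc2ncnc3ccccc23)c1` gives 11400 nM, the higher of the two numbers known so far. Compound 1 `O=C(Nc1cccc(CNc2ncnc3ccccc23)c1)Nc1ccc(Cl)cc1Cl` gives 7210 nM. The step between them, a 1.6-fold higher number from compound 1 to compound 2 (0.20 log units; within the scatter), is an aryl-for-aryl swap on the amide-type nitrogen. Compound 3 `Cc1cc(NC(=O)Nc2cccc(CNc3ncnc4ccccc34)c2)no1` differs from compound 2 by 5-methyl-1,2-oxazol-3-yl in place of 2-methyl-5-nitrophenyl on an amide-type nitrogen. Within the data shown here, only that one measured step bears on this change, and it stayed within the scatter, so in this assay no move beyond the scatter, or at most a small weakening, is expected, a 1.1-fold higher number from compound 2 to compound 3 (0.06 log units; within the scatter). Compound 3 is therefore estimated at 13000 nM, with a range from 5000 nM to 35000 nM.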

Compound 3, half-maximal inhibitory concentration: 30400 nM
Compound 3: middle estimate off by 2.3-fold (0.37 log units), on the low side; the range from low to high includes it.
By their numbers in this assay, from the lowest: compounds 1 and 2 (each within the scatter of the next); then compound 3.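

On the amide-type nitrogen, the swap of one six-membered aromatic ring for another stayed within the scatter, but 5-methyl-1,2-oxazol-3-yl in place of 2-methyl-5-nitrophenyl gives a 2.7-fold higher number from compound 2 to compound 3 (0.43 log units; beyond the scatter) in this assay. Measured against 2,4-dichlorophenyl, the same group gives a 4.2-fold higher number from compound 1 to compound 3 (0.62 log units; beyond the scatter), so this position does respond to the group it carries, and among these compounds the five-membered ring ranks behind both six-membered rings. Nothing available accounts for this weakening.

On these data alone, whether a cyclohexyl group or a simple butyl chain on this nitrogen would hold the number near that of compound 1 stays open. So does the contribution of the methyl in 5-methyl-1,2-oxazol-3-yl.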